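This account rests on a few compounds, and the source may have more. Where it says the series, first, only, none or still open, it means among the compounds named here.

Compound 1 `COc1cc2c(Oc3ccc(NC(=O)c4cc(-c5ccc(F)cc5)ccn4)cc3F)ccnc2cc1OCCCN1CCN(C)CC1` was examined in a functional assay on NCI-H460 cells (Homo sapiens) for cytotoxicity, read by MTT assay, with a stated time of 72 h (on this read-out higher numbers stand for weaker inhibition and lower numbers for stronger inhibition), where compound 1 gives 430 nM. Compound 2 `COc1cc2c(Oc3ccc(NC(=O)c4cc(-c5ccccc5F)ccn4)cc3F)ccnc2cc1OCCCN1CCN(C)CC1` differs from compound 1 only by 2-fluorophenyl in place of 4-fluorophenyl on an aromatic carbon, and in this assay compound 2 gives 140 nM, so that the change brought a 3.1-fold lower number from compound 1 to compound 2 (0.49 log units; beyond the scatter). Compound 3 `COc1cc2c(Oc3ccc(NC(=O)c4cc(-c5ccc(F)cc5)ccn4)cc3F)ccnc2cc1OCCCN1CCCC1` carries a different core, set apart from compound 1 by pyrrolidin-1-yl in place of 4-methylpiperazin-1-yl on a saturated chain carbon, three bonds along the chain from an oxygen on an aromatic ring; in this assay compound 3 gives 370 nM, and the step was a 1.2-fold lower number from compound 1 to compound 3 (0.07 log units; within the scatter). Compound 4 `COc1cc2c(Oc3ccc(NC(=O)c4cc(-c5ccccc5F)ccn4)cc3F)ccnc2cc1OCCCN1CCCC1` has not yet been measured. It differs from compound 3 by 2-fluorophenyl in place of 4-fluorophenyl on an aromatic carbon, the same change that separates compound 2 from compound 1, made at the same place and on the same aromatic carbon. Within the data shown here, the only guide is the single earlier step, and on that basis a step of about the same size is expected, namely a 2.8-fold lower number from compound 3 to compound 4 (0.45 log units; beyond the scatter), because the earlier change brought a 3.1-fold lower number from compound 1 to compound 2 (0.49 log units; beyond the scatter). The core change, by contrast, gave only a 1.2-fold lower number from compound 1 to compound 3 (0.07 log units; within the scatter). Compound 4 is therefore estimated at 130 nM, with a range from 60 nM to 280 nM.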

Compound 4, half-maximal inhibitory concentration: 140 nM
Compound 4: middle estimate off by 1.1-fold (0.03 log units), on the low side, and the stated range covers the measured number.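

In this assay, 2-fluorophenyl in place of 4-fluorophenyl gave a 2.6-fold lower number from compound 3 to compound 4 (0.42 log units; beyond the scatter) on the core bearing pyrrolidin-1-yl, and this step agrees with the one on the core bearing 4-methylpiperazin-1-yl: the same change on two cores in this assay, a 3.1-fold lower number (0.49 log units; beyond the scatter) from compound 1 to compound 2 and a 2.6-fold lower number (0.42 log units; beyond the scatter) from compound 3 to compound 4, 1.2-fold (0.07 log units) apart, within the scatter of two such steps. With 2-fluorophenyl present, pyrrolidin-1-yl in place of 4-methylpiperazin-1-yl gave no change at the digits printed from compound 2 to compound 4 (within the scatter), which agrees with the same exchange made with 4-fluorophenyl present, so across these four compounds the two changes add up without visibly affecting each other: the same change on two cores in this assay, a 1.2-fold lower number (0.07 log units; within the scatter) from compound 1 to compound 3 and no change at the digits printed (within the scatter) from compound 2 to compound 4, 1.2-fold (0.07 log units) apart, within the scatter of two such steps. This shows the fluorine change carrying over between these two cores in this one cell assay, but it does not show that the step would hold on any other core or on another read-out, and it does not explain why the number moves.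

The compounds shown leave open whether a chlorophenyl or an unsubstituted phenyl at the same place would give a similar step. They also leave open whether a morpholine or a shorter chain at the other end of the molecule would leave that step unchanged.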